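This account rests on a few compounds, and the source may have more. Where it says the series, first, only, none or still open, it means among the compounds named here.

Measured compounds in a functional assay on M4Beu cells for cytotoxicity against M4Beu cell line (Homo sapiens), in the presence of a further agent that is not named here; a higher number here means that more compound is needed for the effect, a lower number that less compound is needed:
compound 1 `CC(=O)Nc1nc(OCc2ccc(I)cc2)c2ncn(C3O[C@H](O)[C@@H](O)[C@H]3O)c2n1`: 82 uM
compound 2 `CC(=O)Nc1nc(OCc2ccc(I)cc2)c2ncn(C3CC(O)C(O)O3)c2n1`: 269 uM
compound 3 `Nc1nc(OCc2ccc(Br)cc2)c2ncn(C3O[C@H](O)[C@@H](O)[C@H]3O)c2n1`: 277 uM

Compound 4 `Nc1nc(OCc2ccc(Br)cc2)c2ncn(C3CC(O)C(O)O3)c2n1` remains to be measured in this assay.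

Compound 1 and compound 3 share a related core, but how the two cores differ is not broken down here. The change from compound 1 to compound 2 is 4,5-dihydroxyoxolan-2-yl in place of 3,4,5-trihydroxyoxolan-2-yl on an aromatic nitrogen, and it gave a 3.3-fold higher number from compound 1 to compound 2 (0.52 log units; beyond the scatter). Compound 4 is made from compound 3 by the same change, (4,5-dihydroxyoxolan-2-yl in place of 3,4,5-trihydroxyoxolan-2-yl on an aromatic nitrogen), at a place described in the same words.

Compound 3 and compound 2 give numbers that lie within the scatter of each other, so nothing separates them; compound 3 stands apart from compound 1 only. Since one earlier example of this change is available, the expectation for compound 4 rests on it alone: the step from compound 3 to compound 4 is estimated as a 2.7-fold higher number from compound 3 to compound 4 (0.43 log units; beyond the scatter), set against the measured 3.3-fold higher number from compound 1 to compound 2 (0.52 log units; beyond the scatter). On that basis compound 4 is expected to give about 750 uM in this assay, with a range from 300 uM to 2000 uM, and a real chance that only a limit is reported.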

Compound 4, concentration for half-maximal effect: 4 uM
Compound 4: the middle estimate sits 190-fold (2.27 log units) above what was measured, and the stated range ends above it.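

In this assay, placing 4,5-dihydroxyoxolan-2-yl in place of 3,4,5-trihydroxyoxolan-2-yl on the aromatic nitrogen gives a 69-fold lower number from compound 3 to compound 4 (1.84 log units; beyond the scatter), which runs opposite to the result of the same change on the core of compound 1. The change therefore does not carry over between these two cores, in either direction or size: the same change on two cores in this assay, a 3.3-fold higher number (0.52 log units; beyond the scatter) from compound 1 to compound 2 and a 69-fold lower number (1.84 log units; beyond the scatter) from compound 3 to compound 4, 230-fold (2.36 log units) apart, beyond the scatter of two such steps

With only one pair on each core, this shows that the outcome of the change depends on the core among these four compounds, but it does not show which difference between the cores decides the outcome, or whether either direction is typical of the series.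

It remains open whether the reversal follows the acetyl group on the amino group or the exchange of iodine for bromine on the benzyl ether, as no pair shown separates the two. Also open, on these data alone, is how an amine or a methoxy group in place of a hydroxyl on the oxolane ring would behave on either core.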